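Amino in place of chloro on the shared core

This account rests on a few compounds, and the source may have more. Where it says the series, first, only, none or still open, it means among the compounds named here.

Compound 1 `ClCc1ccccc1Cn1cnc2c(Cl)nc(Cl)nc21` gives 1540 nM in a functional assay on RPMI-8226 cells (Homo sapiens) for cytotoxicity, read by sulforhodamine B assay, with a stated time of 48 h (a higher number here means a weaker inhibitor of growth, a lower number a stronger inhibitor of growth), the lowest of the two numbers in hand; compound 2 `ClCc1cccc(Cn2cnc3c(Cl)ncnc32)c1` gives 16200 nM. Compound 3 `ClCc1cccc(Cn2cnc3c(Cl)nc(Cl)nc32)c1` reaches only the limit > 100000 nM in this assay (the limit of > 100000 nM in this assay, at which 1 of the 3 values shown sits). Compound 4 `Nc1nc(Cl)c2ncn(Cc3ccccc3CCl)c2n1` differs from compound 1 by amino in place of chloro on an aromatic carbon. Within the data shown here, no measured step makes this same exchange; the one step on the core, an at least 6.1-fold higher number from compound 2 to compound 3 (0.79 log units; beyond the scatter), is chloro in place of hydrogen on an aromatic carbon, a different exchange, and so guides only loosely. With nothing directly comparable, the step from compound 1 to compound 4 is expected to stay near the scatter, and compound 4 is estimated at 1500 nM within a range of 400 nM to 6000 nM, meaning a 1.0-fold lower number from compound 1 to compound 4 (0.01 log units; within the scatter).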

Compound 4, concentration for total growth inhibition: > 100000 nM
Compound 4: a limit, no number (the forecaster's own chance of this, stated with the estimate: 10%); middle value at least 66-fold (1.82 log units) from the limit.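

On the aromatic carbon between two ring nitrogen atoms, amino in place of chloro gives an at least 64-fold higher number from compound 1 to compound 4 (1.81 log units; beyond the scatter) in this assay and so marks this position as sensitive to the exchange on the core of compound 1. Among these compounds, the earlier step covered only chloro in place of hydrogen, so this is the first sign of what amino does here. Compound 4 stands at a limit, not a number: the limit of > 100000 nM in this assay, at which 2 of the 4 values shown sit.

How far the step extends past that limit cannot be read. From the compounds shown here alone, whether a methoxy or a dimethylamino group on this carbon would stay near compound 1 remains open.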